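This account rests on a few compounds, and the source may have more. Where it says the series, first, only, none or still open, it means among the compounds named here.

Measured so far:
Compound 1 `Cc1ccc(C)c(-c2nc(CN3CCC(C(=O)NCCCN4C[C@H](C)C[C@H](C)C4)CC3)c(C)o2)c1` — 0.5 h
Compound 2 `Cc1ccccc1-c1nc(CN2CCC(C(=O)NCCCN3CCCC(C(C)C)C3)CC2)c(C)o1` — 0.323 h

In an ADME assay on microsomes from liver (Rattus norvegicus) for metabolic stability, read by LC-MS, using NADPH, at 37 degrees C (on this read-out higher numbers stand for a longer-lived compound and lower numbers for a shorter-lived compound), compound 1 gives 0.5 h. Of the two numbers, compound 1 holds the nominally greater one, but its gap to compound 2 lies within the usual scatter, so the two compounds are not separated. Compound 3 `Cc1ccc(-c2nc(CN3CCC(C(=O)NCCCN4C[C@H](C)C[C@H](C)C4)CC3)c(C)o2)cc1` differs from compound 1 by 4-methylphenyl in place of 2,5-dimethylphenyl on an aromatic carbon. Within the data shown here, no step between measured compounds is available to guide the size of this change. The expectation is that the step of a 1.3-fold lower number from compound 1 to compound 3 (0.10 log units; within the scatter) stays within the scatter, with no clear direction. Compound 3 is therefore estimated at 0.4 h, with a range from 0.2 h to 0.8 h.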

Compound 3, half-life: > 0.5 h
Compound 3: a limit, no number; the forecaster's own chance of this, stated with the estimate: 5%; middle value at least 1.2-fold (0.09 log units) away from the limit.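

In this assay, 4-methylphenyl in place of 2,5-dimethylphenyl on an aromatic carbon of the five-membered aromatic ring gives a number no lower from compound 1 to compound 3 (the limit leaves the size open). Among these compounds, this is the first step at this position, and it shows that the half-life does not fall with this change. The read-out of compound 3 is a limit and not a number: the limit of > 0.5 h in this assay, at which 1 of the 3 values shown sits.

The compounds shown leave open how far compound 3 lies past its limit. They also leave open whether an unsubstituted phenyl or a 4-methoxyphenyl group at this position would hold the half-life.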